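Pyridinone EP3 Ligands: From Hydantoinylmethyl to an Unsaturated Analogue

The compounds below may be only part of what the source reports. "The series", "measured", "known", "first", "only" and "open" are said of these compounds alone.

Compound 1 `CC(C)C(c1ccc(-c2ccc3cccc(F)c3c2)[nH]c1=O)C1SC(=O)NC1=O` and compound 2 `CC(C)C(CC1NC(=O)NC1=O)c1ccc(-c2ccc3cccc(F)c3c2)[nH]c1=O` share a core and differ in one place. In an assay on membranes from Chem-1 cells for displacement of a labelled ligand from prostaglandin E2 receptor EP3 subtype (Homo sapiens), read by scintillation counting, with a stated time of 2 h (on this read-out lower numbers stand for stronger inhibition and higher numbers for weaker inhibition), compound 1 gives 25 nM, while compound 2 gives 10 nM; the change was a 2.5-fold lower number from compound 1 to compound 2 (0.40 log units; beyond the scatter). Going by the values given here, compound 2 thus stands at the lowest of the two numbers measured so far.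

Compound 3 `CC(C)C(/C=C1/C(=O)NC(=O)N1C)c1ccc(-c2ccc3cccc(F)c3c2)[nH]c1=O` differs from compound 2 as follows: a group of 9 heavy atoms (5 carbon, 2 nitrogen, 2 oxygen; one five-membered non-aromatic ring with 2 hetero atoms) in place of a group of 8 heavy atoms (4 carbon, 2 nitrogen, 2 oxygen; one five-membered non-aromatic ring with 2 hetero atoms), on a saturated chain carbon bound to an aromatic carbon and a saturated chain carbon. Among the compounds with values here, only one measured step, a 2.5-fold lower number from compound 1 to compound 2 (0.40 log units; beyond the scatter), bears on this part of the molecule, and it shows that exchanging the ring attached at this place shifts the number modestly. The new group in compound 3 keeps the ring size and heteroatom count but loses one hydrogen-bond donor and gains a double bond outside the ring, so a modest change in either direction is plausible, with a drift toward a higher number considered somewhat more likely. Compound 3 is therefore expected to give 20 nM in this assay, within 5 nM to 80 nM, which would mean a step of a 2.0-fold higher number from compound 2 to compound 3 (0.30 log units; within the scatter).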

Compound 3, inhibition constant in the prostaglandin E2 receptor EP3 subtype assay: 6 nM
Estimate against measurement, compound 3: 3.3-fold (0.52 log units) above; the measured number falls inside the stated range.
By their numbers in the prostaglandin E2 receptor EP3 subtype assay, from the lowest: compounds 3 and 2 (each within the scatter of the next); then compound 1.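

In the prostaglandin E2 receptor EP3 subtype assay, the group entering in compound 3 differs from (2,5-dioxoimidazolidin-4-yl)methyl in its counts of double bonds and hydrogen-bond donors, yet the result is a 1.7-fold lower number from compound 2 to compound 3 (0.22 log units; within the scatter), so this place accepts that change without a shift beyond the scatter. Against the 2,4-dioxo-1,3-thiazolidin-5-yl group of compound 1, the same group gives a 4.2-fold lower number from compound 1 to compound 3 (0.62 log units; beyond the scatter), which is the largest step seen so far at this position. In a physicochemical assay for solubility, measured as kinetic solubility, at pH 2 (a higher number here means a more soluble compound, a lower number a less soluble compound), compound 2 gives 13000 nM and compound 3 gives 8300 nM, and this pair shows a 1.6-fold lower number from compound 2 to compound 3 (0.19 log units; within the scatter), so the change stays within the scatter on both read-outs.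

Nothing available accounts for these numbers. From the compounds shown here alone, how a carboxylic acid or an amine would read at this place remains open in both assays.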